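Hydroxyethyl analogue of compound 3: expected plasma protein binding

The source may report more compounds than this note shows. Statements on the series, on what has been measured and on what is new or still open speak of the compounds shown alone.

In an ADME assay on a cell-free system (plasma, Homo sapiens) for protein binding, compound 3 `CCc1nc2nc(C)cc(Nc3ccc(C(F)(F)F)cc3)n2n1` gives 87.5%, the second highest of the three unbound fractions. Its nearest neighbour is compound 2 `Cc1cc(Nc2ccc(C(F)(F)F)cc2)n2nc(C3CC3)nc2n1`, which gives 92.8%; furthest away is compound 1 `COCc1nc2nc(C)cc(Nc3ccc(C(F)(F)F)cc3)n2n1`, which gives 75.6%. Compound 4 `Cc1cc(Nc2ccc(C(F)(F)F)cc2)n2nc(CCO)nc2n1` differs from compound 3 by hydroxy in place of hydrogen on a saturated chain carbon, two bonds along the chain from an aromatic carbon. The step that bears on this change is the reverse of adding oxygen to the chain: a 2.0-fold lower unbound fraction from compound 1 to compound 3 (0.29 log units; within the scatter). The other steps, a 3.4-fold lower unbound fraction from compound 1 to compound 2 (0.53 log units; beyond the scatter) and a 1.7-fold higher unbound fraction from compound 2 to compound 3 (0.24 log units; within the scatter), concern the ring and chain groups rather than an oxygen. A rise in unbound fraction of about the size of the methoxy step, near the edge of the scatter, is expected for compound 4. For compound 4 the estimate is 74%, range 58% to 85%, meaning an expected a 2.1-fold higher unbound fraction from compound 3 to compound 4 (0.32 log units; beyond the scatter).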

Compound 4, plasma protein binding: 67%
Estimate against measurement, compound 4: 1.3-fold (0.10 log units) (unbound fraction) below; the range from low to high includes it.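

In this assay, hydroxy in place of hydrogen on this saturated chain carbon gives a step beyond the scatter: a 2.6-fold higher unbound fraction from compound 3 to compound 4 (0.42 log units; beyond the scatter). Replacing cyclopropyl with 2-hydroxyethyl gives a 4.6-fold higher unbound fraction from compound 2 to compound 4 (0.66 log units; beyond the scatter). The hydroxyethyl and methoxymethyl chains are not separated, with a 1.4-fold higher unbound fraction from compound 1 to compound 4 (0.13 log units; within the scatter) lying within the scatter.

From the compounds shown here alone, whether an amine, a carboxylic acid or a longer chain ending in hydroxy would shift the binding as far remains open. No measurement available here explains the shift seen with hydroxy.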